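Ethynyl in place of formyl on the shared core

The source may hold more compounds than are shown below. What is called first, only, known or untested is meant among the compounds shown, and "the series" means these compounds.

Measured so far in an ADME assay on HEK293 cells (Homo sapiens) for cytotoxicity, read by MTT assay, with a stated time of 48 h; on this read-out higher numbers stand for weaker inhibition and lower numbers for stronger inhibition
compound 1 `C=C1CCC[C@]2(C)CCC(C=O)=CC[C@@]12C` - 734000 nM
compound 2 `CC1(C)CCCC2=CC=C(C=O)CC[C@]21C` - 696000 nM

Compound 1 stands level with compound 2, as the two values lie within the scatter. Compound 3 `C#CC1=CC[C@@]2(C)C(=C)CCC[C@]2(C)CC1` is still unmeasured and has ethynyl in place of formyl on a double-bonded ring carbon. For the measured compounds named here, no measured pair covers this change, so the data give no direction for it. With compound 1 at 734000 nM as the anchor, no step beyond the scatter is expected in this assay. The estimated 1.2-fold lower number from compound 1 to compound 3 (0.09 log units; within the scatter) is correspondingly small. For compound 3 the expected value is 600000 nM, with an estimated range of 200000 nM to 1500000 nM.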

Compound 3, half-maximal inhibitory concentration: 524000 nM
Beside the measured number, compound 3's estimate is 1.1-fold (0.06 log units) above it; the range from low to high includes it.
By their numbers in this assay, from the lowest: compounds 3, 2 and 1 (each within the scatter of the next).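

In this assay, for the compounds shown here, ethynyl in place of formyl on a double-bonded ring carbon gives a 1.4-fold lower number from compound 1 to compound 3 (0.15 log units; within the scatter) and is the first single-place step read. At this place on the seven-membered ring, the formyl group and its hydrogen-bond acceptor can therefore be exchanged for ethynyl with no step beyond the scatter. Nothing available explains this result. Still open, on these data alone, is how an amine, a carboxylic acid or a longer chain would read at this place, and whether the same exchange on the core of compound 2 would read alike.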